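Carboxy in Place of Hydroxymethyl, Judged Against Three Limits

The source may report more compounds than this note shows. Statements on the series, on what has been measured and on what is new or still open speak of the compounds shown alone.

Compound 1 `CC(=O)O[C@H](C/C(C)=C/CO)[C@@]1(C)[C@H](C)CC=C2[C@@H]1CCCC2(C)C`: > 30000 nM
Compound 2 `CCCC(=O)OC/C=C(\C)C[C@@H](O)[C@@]1(C)[C@H](C)CC=C2[C@@H]1CCCC2(C)C`: > 30000 nM
Compound 3 `C/C(=C\CO)C[C@@H](O)[C@@]1(C)[C@H](C)CC=C2[C@@H]1CCCC2(C)C`: > 30000 nM

The three compounds were tested in a functional assay on HL-60 cells (Homo sapiens) for cytotoxicity, read by MTT assay, with a stated time of 72 h; a higher number here means a weaker inhibitor, a lower number a stronger inhibitor. Compound 1 returned only a limit of this assay. Compound 2 likewise returned only a limit. Compound 3 returned only a limit as well, so that the limit of > 30000 nM in this assay, at which 3 of the 3 values shown sit, sums up everything measured. Compound 1 therefore stands at the edge of what this assay reports, and the other two compounds show nothing beyond that edge.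

Compound 4 `CC(=O)O[C@H](C/C(C)=C/C(=O)O)[C@@]1(C)[C@H](C)CC=C2[C@@H]1CCCC2(C)C` differs from compound 1 in one place: carboxy in place of hydroxymethyl on a double-bonded chain carbon bound to a double-bonded chain carbon. Of the measured steps, a step that the two limits leave unreadable from compound 1 to compound 3 and a step that the two limits leave unreadable from compound 2 to compound 3 are the only ones, and both change a group on an oxygen on a saturated carbon, not the chain end that is altered here. They bear on the new step only in that neither could be read at all. Among the compounds with values here, no measured step tells how this assay responds to the carboxy in place of hydroxymethyl, so there is no ground for expecting a step beyond the scatter in either direction.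

Compound 4 is therefore expected to give 50000 nM, ranging from 15000 nM to 200000 nM, most likely again as a limit. The expected step that the limit leaves unreadable from compound 1 to compound 4 is thus essentially none.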

Compound 4, half-maximal inhibitory concentration: > 30000 nM
Compound 4 was reported as a limit (the forecaster's own chance of this, stated with the estimate: 85%); the middle value lies beyond the limit too.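

Compound 1 and compound 4 each returned only a limit, so the step between them, carboxy in place of hydroxymethyl, cannot be read: the limit of > 30000 nM in this assay, at which 4 of the 4 values shown sit.

The compounds shown leave open what this change does in this assay, and which change to the shared core, if any, would give a readable value.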